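The source may report more compounds than this note shows. Statements on the series, on what has been measured and on what is new or still open speak of the compounds shown alone.

Working notes on the series. Compound 1 `Cc1ccccc1COc1ccccc1C(=O)Nc1cccnc1` and compound 2 `O=C(Nc1cccnc1)c1ccccc1OCc1cccc(Cl)c1` share one core and differ only in the group on the saturated chain carbon bound to an oxygen on an aromatic ring. In an assay on lysate for inhibition of phosphatidylcholine:ceramide cholinephosphotransferase 2 (Homo sapiens), read by HPLC, with stated times of 30 min and 2 h (on this read-out higher numbers stand for weaker inhibition and lower numbers for stronger inhibition), compound 1 gives 1500 nM and compound 2 gives 1400 nM; the step of a 1.1-fold lower number from compound 1 to compound 2 (0.03 log units; within the scatter) lies within the scatter. Of the two numbers shown, compound 2 stands at the lowest, yet its gap to compound 1 is within the scatter, so the two are not told apart. Compound 3 `O=C(Nc1cccnc1)c1ccccc1OCc1cc(F)ccc1Cl` carries 2-chloro-5-fluorophenyl in place of 3-chlorophenyl on a saturated chain carbon bound to an oxygen on an aromatic ring. For the measured compounds named here, the only measured step that bears on this change is a 1.1-fold lower number from compound 1 to compound 2 (0.03 log units; within the scatter), a swap at the same place that showed nothing beyond the scatter; no measured step tests a fluorine on that ring. The expected step of no change at the digits printed from compound 2 to compound 3 (within the scatter) in this assay is therefore none beyond the scatter. Compound 3 is estimated at 1400 nM, with a range from 500 nM to 4000 nM.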

Compound 3, half-maximal inhibitory concentration: 740 nM
Compound 3: the middle estimate sits 1.9-fold (0.28 log units) above what was measured, and the stated range covers the measured number.
By their numbers in this assay, from the lowest: compounds 3, 2 and 1 (each within the scatter of the next, the first and the last beyond it).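

For the compounds shown here, at the saturated chain carbon bound to an oxygen on an aromatic ring, 2-chloro-5-fluorophenyl in place of 2-methylphenyl gives a 2.0-fold lower number from compound 1 to compound 3 (0.31 log units; beyond the scatter) in this assay, the first step at this place to pass the scatter, though only modestly. 2-Chloro-5-fluorophenyl in place of 3-chlorophenyl gives a 1.9-fold lower number from compound 2 to compound 3 (0.28 log units; within the scatter), so compound 2 and compound 3 are not told apart, and the differences between these two groups cannot be read separately. No measurement shown offers an explanation for these numbers.

As far as these compounds go, it remains open whether the chlorine, the fluorine or both in 2-chloro-5-fluorophenyl account for the step from the 2-methylphenyl compound. Also open, from the compounds shown here alone, is how a methoxy group, an amine or a carboxylic acid on this ring would read in this assay.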